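A few compounds are considered here, and "the series" means these few. Any claim that something is new, unique, unknown or untested is made for them only; others in the source may bear on it.

In a functional assay (blood) for inhibition, with Homo sapiens as the target (on this read-out lower numbers stand for stronger inhibition and higher numbers for weaker inhibition), compound 2 (`CC(C)(C)Sc1c(CC(C)(C)C(=O)O)n(Cc2ccc(Cl)cc2)c2ccc(OCc3cccc(Cl)n3)cc12`) gives 410 nM and compound 3 (`C[C@@H](COc1ccc2c(c1)c(SC(C)(C)C)c(CC(C)(C)C(=O)O)n2Cc1ccc(Cl)cc1)c1ccccn1`) gives 280 nM. These two values cannot be separated: a 1.5-fold lower number from compound 2 to compound 3 (0.17 log units; within the scatter). Compound 1 (`CC(C)(C)Sc1c(CC(C)(C)C(=O)O)n(Cc2ccc(Cl)cc2)c2ccc(OCc3cccnc3)cc12`) returns only a limit, > 3000 nM. The steps that start from compound 1 are therefore bounds: an at least 7.3-fold lower number from compound 1 to compound 2 (0.86 log units; beyond the scatter) and an at least 10-fold lower number from compound 1 to compound 3 (1.02 log units; beyond the scatter).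

Compound 4 (`CC(C)(C)Sc1c(CC(C)(C)C(=O)O)n(Cc2ccc(Cl)cc2)c2ccc(OCc3cccs3)cc12`) carries thiophen-2-yl in place of 1-(pyridin-2-yl)ethyl on a saturated chain carbon bound to an oxygen on an aromatic ring. Going by the values given here, all the measured steps fall at this same place, so all of them bear on the change. Among the compounds with values here, no compound with thiophen-2-yl has been measured, so the direction rests on limited evidence.

The bound an at least 10-fold lower number from compound 1 to compound 3 (1.02 log units; beyond the scatter) shows that a change at this place can move the number a long way, while a 1.5-fold lower number from compound 2 to compound 3 (0.17 log units; within the scatter) shows that two different groups there can give matching values. A modest move to a higher number in this assay is therefore expected, with wide uncertainty. The expected step is a 2.1-fold higher number from compound 3 to compound 4 (0.33 log units; beyond the scatter). For compound 4 the estimated value is 600 nM, with an expected range of 180 nM to 2500 nM.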

Compound 4, half-maximal inhibitory concentration: > 3000 nM
Compound 4 ended at the assay's limit; the forecaster's own chance of this, stated with the estimate: 15%; at least 5.0-fold (0.69 log units) between middle value and limit.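

In this assay compound 4 gives > 3000 nM, which is a limit of the assay and not a number. The steps of an at least 10-fold higher number from compound 3 to compound 4 (1.02 log units; beyond the scatter) and an at least 7.3-fold higher number from compound 2 to compound 4 (0.86 log units; beyond the scatter) are both bounds beyond the scatter, so the place on a saturated chain carbon bound to an oxygen on an aromatic ring does not accept every aromatic ring: thiophen-2-yl now joins pyridin-3-yl at the limit, and among these four compounds only the two pyridin-2-yl groups, in compound 2 and compound 3, give readable values. The step between compound 1 and compound 4 cannot be read, because both stop at the same limit: the limit of > 3000 nM in this assay, at which 2 of the 4 values shown sit.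

From the compounds shown here alone, how far compound 1 and compound 4 actually lie beyond that limit stays open, so these two groups cannot be ranked against each other. Compound 4 differs from compound 3 in ring size, hetero atom and stereocentre at once, and a plain phenyl ring or a pyridin-4-yl group at this place would help to show which of these differences goes with the loss.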